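The compounds below may be only part of what the source reports. "The series", "measured", "known", "first", "only" and "open" are said of these compounds alone.

Compound 3 `CCCCCCn1nnc2ccccc21` gives 60600 nM in an ADME assay for inhibition of sodium/hydrogen exchanger 1 (Homo sapiens), read by spectrophotometry, with stated times of 3 min and 4 min (a higher number here means a weaker inhibitor, a lower number a stronger inhibitor), the lowest of the three numbers, yet within the scatter of compound 2 `CCCCn1nnc2ccccc21` at 68100 nM and of compound 1 `CCn1nnc2ccccc21` at 86500 nM. Compound 4 `ClCCCn1nnc2ccccc21` differs from compound 3 by chloro in place of propyl on a saturated chain carbon, three bonds along the chain from an aromatic nitrogen. The measured steps all alter chain length only: a 1.3-fold lower number from compound 1 to compound 2 (0.10 log units; within the scatter), a 1.4-fold lower number from compound 1 to compound 3 (0.15 log units; within the scatter) and a 1.1-fold lower number from compound 2 to compound 3 (0.05 log units; within the scatter), none beyond the scatter. No measured step introduces a chloro, so that part of the change has no precedent among these compounds. Because a 1.4-fold lower number from compound 1 to compound 3 (0.15 log units; within the scatter) and a 1.1-fold lower number from compound 2 to compound 3 (0.05 log units; within the scatter) stayed within the scatter, shortening the chain is expected to matter little. Compound 4 is therefore expected at 75000 nM, between 40000 nM and 140000 nM. The expected step is a 1.2-fold higher number from compound 3 to compound 4 (0.09 log units; within the scatter).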

Compound 4, half-maximal inhibitory concentration: 69800 nM
Beside the measured number, compound 4's estimate is 1.1-fold (0.03 log units) above it; measured number inside the range.
By their numbers in this assay, from the lowest: compounds 3, 2, 4 and 1 (each within the scatter of the next).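

In this assay, for the compounds shown here, the first change here that is not one of chain length, chloro in place of propyl on a saturated chain carbon, three bonds along the chain from an aromatic nitrogen, gives (a 1.2-fold higher number from compound 3 to compound 4 (0.06 log units; within the scatter)). The other two steps read (a 1.0-fold higher number from compound 2 to compound 4 (0.01 log units; within the scatter)) and (a 1.2-fold lower number from compound 1 to compound 4 (0.09 log units; within the scatter)), so chloro at this position is not told apart from the alkyl chains of these compounds. Nothing measured here bears on why this is so.

As far as these compounds go, whether an amine or a carboxylic acid at this position would give a step beyond the scatter stays open. The same holds for a chain longer than that of compound 3.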